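This account rests on a few compounds, and the source may have more. Where it says the series, first, only, none or still open, it means among the compounds named here.

In a functional assay on MCF7 cells (Homo sapiens) for antiproliferative activity, read by MTT assay, with a stated time of 72 h (a lower number here means a stronger inhibitor, a higher number a weaker inhibitor), compound 1 `O=S1(=O)C=Cc2ccc(Nc3cccc(C(F)(F)F)c3)cc21` gives 2500 nM and compound 2 `O=S1(=O)C=Cc2cccc(Nc3ccc(OC(F)(F)F)cc3)c21` gives 2690 nM, so compound 2 stands level with compound 1, within the usual scatter of repeated measurements. Compound 3 `COc1ccc(Nc2cccc3c2S(=O)(=O)C=C3)cc1` differs from compound 2 in one place, trifluoromethoxy to methoxy: methyl in place of trifluoromethyl on an oxygen on an aromatic ring. That is methyl in place of trifluoromethyl on an oxygen on an aromatic ring. Within the data shown here, no two measured compounds differ in only one place, so the data offer no direct guide. In this assay no shift beyond the scatter is expected, and the estimated change is a 1.3-fold higher number from compound 2 to compound 3 (0.11 log units; within the scatter). For compound 3 the estimated value is 3500 nM, with an expected range from 1200 nM to 10000 nM.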

Compound 3, half-maximal inhibitory concentration: 940 nM
Compound 3: middle estimate off by 3.7-fold (0.57 log units), on the high side; the measured number lies below the stated range.
By their numbers in this assay, from the lowest: compound 3; then compounds 1 and 2 (each within the scatter of the next).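

In this assay, putting methyl in place of trifluoromethyl on the oxygen on an aromatic ring gives a 2.9-fold lower number from compound 2 to compound 3 (0.46 log units; beyond the scatter). Among these compounds, this is the first step here that changes a single place, and it shows that the number responds to what sits on this oxygen. Nothing measured here gives a reason for the step. Still open, from the compounds shown here alone, is whether a longer chain such as ethyl on that oxygen would lower the number further or raise it again. Also open, going by these compounds, is whether an amine in place of the methoxy would keep the lower number.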